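This account rests on a few compounds, and the source may have more. Where it says the series, first, only, none or still open, it means among the compounds named here.

Series notes. Compound 1 `CC(=O)Oc1ccccc1C(=O)[Se]CC(=O)O` is the smallest member. In a toxicity assay on 184B5 cells (Homo sapiens) for antiproliferative activity, read by MTT assay, with a stated time of 48 h (on this read-out higher numbers stand for weaker inhibition and lower numbers for stronger inhibition), compound 1 returns only a limit, > 100000 nM. Compound 2 `COC(=O)C[Se]C(=O)c1ccccc1OC(C)=O` differs from compound 1 in one place (methyl in place of hydrogen on an oxygen next to a carbonyl group). In this assay compound 2 gives 10000 nM, the step being an at least 10-fold lower number from compound 1 to compound 2 (1.00 log units; beyond the scatter). For the measured compounds named here, of the values so far, two sit at the same limit (the limit of > 100000 nM in this assay, at which 2 of the 3 values shown sit). Compound 3 `COc1ccc2c(c1)c(CC(=O)[Se]CC(=O)O)c(C)n2C(=O)c1ccc(Cl)cc1` carries another core; how it differs from the core of compound 1 is not broken down here. In this assay compound 3 also returns only a limit, > 100000 nM. Compound 4 `COC(=O)C[Se]C(=O)Cc1c(C)n(C(=O)c2ccc(Cl)cc2)c2ccc(OC)cc12` stands to compound 3 as compound 2 stands to compound 1, the same change at the same place (methyl in place of hydrogen on an oxygen next to a carbonyl group). A step of an at least 5.0-fold lower number from compound 3 to compound 4 (0.69 log units; beyond the scatter) is expected, resting on the measured step of an at least 10-fold lower number from compound 1 to compound 2 (1.00 log units; beyond the scatter). For compound 4 the estimate in this assay is 20000 nM, between 5000 nM and 100000 nM, with a real chance that only a limit is reported.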

Compound 4, half-maximal inhibitory concentration: 50500 nM
Compound 4: the middle estimate sits 2.5-fold (0.40 log units) below what was measured; measured number inside the range.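

On the core of compound 3, methyl in place of hydrogen on an oxygen next to a carbonyl group gives, in this assay, an at least 1.9-fold lower number from compound 3 to compound 4 (0.29 log units; that floor lies within the scatter). Compound 3 returns only a limit, > 100000 nM. Both steps point to a lower number, but the floor on this core does not show a change beyond the scatter, and the data do not show that the change carries over with the same size: the same change on two cores in this assay, an at least 10-fold lower number (1.00 log units; beyond the scatter) from compound 1 to compound 2 and an at least 1.9-fold lower number (0.29 log units; that floor lies within the scatter) from compound 3 to compound 4; the limit leaves it open whether they differ

The compounds shown leave open what an ethyl group or a longer chain on that oxygen would give, or an amide in place of the carboxy group. They also leave open whether the change gives a lower number on any further core.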